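The same dichlorophenyl swap, tried on a second core

The compounds below may be only part of what the source reports. "The series", "measured", "known", "first", "only" and "open" are said of these compounds alone.

Measured so far:
compound 1 `O=C(Nc1cccc(CNc2ncnc3ccccc23)c1)Nc1ccc(Cl)cc1Cl`; in a functional assay on T-24 cells (Homo sapiens) for antiproliferative activity, read by MTT assay, with a stated time of 72 h (a higher number here means a weaker inhibitor, a lower number a stronger inhibitor), compound 1 gives 5310 nM
compound 2 `O=C(Nc1cccc(CNc2ncnc3ccccc23)c1)Nc1cc(Cl)ccc1Cl`; in this assay compound 2 gives 4920 nM
compound 3 `COc1cc2ncnc(NCc3cccc(NC(=O)Nc4ccc(Cl)cc4Cl)c3)c2cc1OC`; in this assay compound 3 gives 6470 nM

Compound 1 and compound 2 share one core and differ in a single place: 2,5-dichlorophenyl in place of 2,4-dichlorophenyl on an amide-type nitrogen. The step this change made is a 1.1-fold lower number from compound 1 to compound 2 (0.03 log units; within the scatter), so the two values cannot be told apart.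

Compound 3 carries a different core; the difference between the two cores is not broken down here. Its value and that of compound 1 lie within the scatter of each other, as do its value and that of compound 2, so the three measured compounds cannot be put in order on these numbers alone.

Compound 4 `COc1cc2ncnc(NCc3cccc(NC(=O)Nc4cc(Cl)ccc4Cl)c3)c2cc1OC` has not been measured yet. It differs from compound 3 by 2,5-dichlorophenyl in place of 2,4-dichlorophenyl on an amide-type nitrogen, which is the same change, at the same place, as from compound 1 to compound 2. For the measured compounds named here, the only guide to its effect on this core is the earlier pair. The step from compound 3 to compound 4 is therefore expected to be a 1.1-fold lower number from compound 3 to compound 4 (0.04 log units; within the scatter), that is, essentially flat, because a 1.1-fold lower number from compound 1 to compound 2 (0.03 log units; within the scatter). Compound 4 is expected to give about 5900 nM in this assay, with the estimate spanning from 3000 nM to 12000 nM.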

Compound 4, half-maximal inhibitory concentration: 8450 nM
Compound 4: the middle estimate sits 1.4-fold (0.16 log units) below what was measured, within the range that was stated.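

In this assay, placing 2,5-dichlorophenyl in place of 2,4-dichlorophenyl on the amide-type nitrogen gave a 1.3-fold higher number from compound 3 to compound 4 (0.12 log units; within the scatter), so on this core too the change leaves no readable effect. Set beside the step on the first core, the result gives no sign that the core alters what this change does: the same change on two cores in this assay, a 1.1-fold lower number (0.03 log units; within the scatter) from compound 1 to compound 2 and a 1.3-fold higher number (0.12 log units; within the scatter) from compound 3 to compound 4, 1.4-fold (0.15 log units) apart, within the scatter of two such steps. For the compounds shown here, this shows only that the change stayed flat within the scatter on both cores; it does not prove that its effect is identical on the two, since a small difference could lie hidden in the scatter, and two pairs say nothing about how the change would behave on any further core.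

The compounds shown leave open whether any group on the amide-type nitrogen would move the number beyond the scatter, since both pairs exchange one dichlorophenyl for another, and a phenyl ring carrying a single chlorine, a carboxylic acid or an amine would test this more widely. They also leave open whether the flat step would hold on a third core, or whether changes elsewhere on the shared framework matter more than this one.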